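The compounds below may be only part of what the source reports. "The series", "measured", "known", "first", "only" and "open" are said of these compounds alone.

Working notes on the series.

Compound 3 `C#CCSc1nnc(CCC)n1N1C(=O)c2ccccc2C1=O` is the starting point of this step. In a functional assay on MKN-45 cells (Homo sapiens) for cytotoxicity, read by MTT assay, with a stated time of 48 h (on this read-out higher numbers stand for weaker inhibition and lower numbers for stronger inhibition), compound 3 gives only a limit, > 200000 nM, and no number. The two neighbours it is compared with are in the same position. Compound 1 `C=CCSc1nnc(CCC)n1N1C(=O)c2ccccc2C1=O` gives only a limit, > 200000 nM. Compound 2 `CCCc1nnc(SCC(=O)c2ccc(Cl)cc2)n1N1C(=O)c2ccccc2C1=O` likewise gives only a limit, > 200000 nM. The three measured steps are therefore not readable: a step that the two limits leave unreadable from compound 1 to compound 2, a step that the two limits leave unreadable from compound 1 to compound 3 and a step that the two limits leave unreadable from compound 2 to compound 3. The common ground is the limit of > 200000 nM in this assay, at which 3 of the 3 values shown sit.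

Compound 4 `CCCc1nnc(SCc2ccccc2Cl)n1N1C(=O)c2ccccc2C1=O` carries the change (2-chlorophenyl in place of ethynyl on a saturated chain carbon bound to a sulfur). Among the measured compounds, a chlorinated aromatic group on the sulfur-bound chain already appears in compound 2, and the exchange of a small unsaturated chain for a larger one appears between compound 1 and compound 3; neither gave a readable step. For the measured compounds named here, no measured step bears on the change to compound 4, so the step of a number no higher from compound 3 to compound 4 (the limit leaves the size open) is only an estimate with a limit again as the most likely outcome. The value for compound 4 is estimated at 200000 nM, within 50000 nM to 400000 nM.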

Compound 4, half-maximal inhibitory concentration: > 200000 nM
Compound 4: a limit, no number; the forecaster's own chance of this, stated with the estimate: 70%; the middle value sits exactly at the limit.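

In this assay compound 4 gives > 200000 nM, again a limit and not a number. Its steps from compound 1, compound 2 and compound 3 cannot be read. The compounds shown leave open how the groups on the sulfur-bound chain compare, all resting on one common ground: the limit of > 200000 nM in this assay, at which 4 of the 4 values shown sit.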